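A few compounds are considered here, and "the series" means these few. Any claim that something is new, unique, unknown or untested is made for them only; others in the source may bear on it.

Measured in a functional assay on SK-BR-3 cells (Homo sapiens) for cytotoxicity, read by MTT assay, with a stated time of 72 h; on this read-out lower numbers stand for an effect already at smaller amounts and higher numbers for an effect only at larger amounts of compound:

- Compound 1 `CCc1cccc2c(OC)c(-c3occ(C)c3C(=O)OC)ccc12`: 1.2 ug/mL
- Compound 2 `CCOc1c(-c2occ(C)c2C(=O)O)ccc2c(CC)cccc12`: > 10 ug/mL (a limit)
- Compound 3 `CCOc1c(-c2occ(C)c2C(=O)OC)ccc2c(CC)cccc12`: 1.9 ug/mL

Among the measured compounds shown here, compound 3 can be compared with only one other number, and the gap is a 1.6-fold higher number from compound 1 to compound 3 (0.20 log units; within the scatter). Compound 2 reports only a limit, > 10 ug/mL.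

Compound 4 `CCOc1c(-c2occ(C)c2COC)ccc2c(CC)cccc12` has methoxymethyl in place of methoxycarbonyl on an aromatic carbon. For the measured compounds named here, the only measured change at this place is an at least 5.2-fold lower number from compound 2 to compound 3 (0.72 log units; beyond the scatter), which removes the hydrogen on the oxygen next to the carbonyl group. Going by the values given here, compound 4 does not regain that hydrogen, but no measured compound carries methoxymethyl, so the expectation is loose. In this assay, the expected change is a 1.3-fold higher number from compound 3 to compound 4 (0.12 log units; within the scatter), with no step beyond the scatter expected. Compound 4 is estimated at 2.5 ug/mL, within an expected range of 0.9 ug/mL to 8 ug/mL.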

Compound 4, concentration for half-maximal effect: > 10 ug/mL
Compound 4: no number, only a limit; the forecaster's own chance of this, stated with the estimate: 15%; middle value at least 4.0-fold (0.60 log units) away from the limit.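

Putting methoxymethyl in place of methoxycarbonyl on this aromatic carbon gives an at least 5.2-fold higher number from compound 3 to compound 4 (0.72 log units; beyond the scatter) in this assay. The earlier step from the carboxy group of compound 2 left open whether removing that acid hydrogen was enough, and it is not: methoxymethyl also has no hydrogen-bond donor, yet compound 4 reaches only a limit. Of the groups shown here, only methoxycarbonyl, in compound 1 and compound 3, gives a readable number.

The step from compound 2 to compound 4 cannot be read because both values are limits: the limit of > 10 ug/mL in this assay, at which 2 of the 4 values shown sit. As far as these compounds go, whether an amide or a hydroxymethyl group at this place would keep the effect remains open.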